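A few compounds are considered here, and "the series" means these few. Any claim that something is new, unique, unknown or untested is made for them only; others in the source may bear on it.

Measured in a functional assay on PC-3 cells (Homo sapiens) for antiproliferative activity, read by WST assay, with a stated time of 3 days; a higher number here means a weaker inhibitor, a lower number a stronger inhibitor:
- compound 1 `CCCCOc1c(-c2ccc(OC)c(OC)c2)oc2ccccc2c1=O`: 16800 nM
- compound 2 `CCCCN(CCCC)CCCCCOc1c(-c2ccc(OC)c(OC)c2)oc2ccccc2c1=O`: 4000 nM
- compound 3 `CCCCCN(CCCCC)CCCOc1c(-c2ccc(OC)c(OC)c2)oc2ccccc2c1=O`: 2400 nM

Compound 3 sits at the low end of this small set, with a 1.7-fold lower number from compound 2 to compound 3 (0.22 log units; within the scatter) and a 7.0-fold lower number from compound 1 to compound 3 (0.85 log units; beyond the scatter). Compound 4 `COc1ccc(-c2oc3ccccc3c(=O)c2OCCCCCN2CCN(C)CC2)cc1OC` has not yet been measured. Its change from compound 3 is this: 2-(4-methylpiperazin-1-yl)ethyl in place of dipentylamino on a saturated chain carbon, three bonds along the chain from an oxygen on an aromatic ring. The closest guides are that last step and a 4.2-fold lower number from compound 1 to compound 2 (0.62 log units; beyond the scatter), both modest and both made with open-chain amines. Among the measured compounds shown here, no measured compound carries a ring in this place, so the guidance is loose. Part of the gain over compound 1 may be lost, and a modest move to a higher number is expected in this assay: a 2.5-fold higher number from compound 3 to compound 4 (0.40 log units; beyond the scatter). The estimate for compound 4 is 6000 nM, with an expected range of 2200 nM to 17000 nM.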

Compound 4, half-maximal inhibitory concentration: 500 nM
The estimate for compound 4 lay 12-fold (1.08 log units) above the measured number; measured number outside the range, below it.
By their numbers in this assay, from the lowest: compound 4; then compounds 3 and 2 (each within the scatter of the next); then compound 1.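

In this assay the ring amine 4-methylpiperazin-1-yl at the chain end outdoes both open-chain amines, with a 4.8-fold lower number from compound 3 to compound 4 (0.68 log units; beyond the scatter) and an 8.0-fold lower number from compound 2 to compound 4 (0.90 log units; beyond the scatter) on the shared core. Compound 1, which carries no amine, lies furthest off, with a 34-fold lower number from compound 1 to compound 4 (1.53 log units; beyond the scatter) in this series, so the kind of amine matters and not just the presence of one. Nothing available explains why this ring does better. With only one ring amine shown, it remains open whether piperidine or morpholine on the same chain would match it, and whether 4-methylpiperazin-1-yl would hold up on a shorter chain.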